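This account rests on a few compounds, and the source may have more. Where it says the series, first, only, none or still open, it means among the compounds named here.

Of the compounds shown here, three of a shared core have been measured in an assay on isolated protein for agonist activity at Toll-like receptor 8 (Homo sapiens); on this read-out lower numbers stand for an effect already at smaller amounts and higher numbers for an effect only at larger amounts of compound. Compound 1 `CCCCNc1nc(N)nnc1OCc1ccccc1OC` gives 640 nM, compound 2 `CCC[C@H](CCO)Nc1nc(N)nnc1OCc1nccc(OC)c1OC` gives 560 nM, and compound 3 `CCCCNc1nc(N)nnc1OCc1ccccn1` gives 330 nM. Compound 3 stands at the lowest of these three numbers, yet its gaps to compound 2 and to compound 1 both lie within the scatter, so no order among them can be read from these data. Compound 4 `CCCCNc1nc(N)nnc1OCCOC` has not been measured. It differs from compound 3 in one place: methoxymethyl in place of pyridin-2-yl on a saturated chain carbon bound to an oxygen on an aromatic ring. Among the measured compounds shown here, with no measured step of this kind to lean on, the step from compound 3 to compound 4 is expected to be a move toward a higher number, roughly a 4.5-fold higher number from compound 3 to compound 4 (0.66 log units; beyond the scatter) in this assay. Compound 4 is therefore estimated at 1500 nM, with a range from 500 nM to 6000 nM.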

Compound 4, half-maximal effective concentration: 1000 nM
Estimate against measurement, compound 4: 1.5-fold (0.18 log units) above; the measured number falls inside the stated range.
By their numbers in this assay, from the lowest: compounds 3, 2, 1 and 4 (each within the scatter of the next, the first and the last beyond it).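

Among the compounds shown here, until now no two compounds in this assay differed in one place, so this is the first reading of any single change. On a saturated chain carbon bound to an oxygen on an aromatic ring, methoxymethyl in place of pyridin-2-yl gives a 3.0-fold higher number from compound 3 to compound 4 (0.48 log units; beyond the scatter) and shows that the number at this position depends on the group it carries, though the step is modest. No measured finding on hand explains this step.

As far as these compounds go, whether an unsubstituted phenyl, a longer alkyl chain or an amine here would fall nearer compound 3 or compound 4 remains open. So does whether the same step would hold with the amine side chain of compound 2.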